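This account rests on a few compounds, and the source may have more. Where it says the series, first, only, none or still open, it means among the compounds named here.

Measured compounds:
Compound 1 `CCOC(=O)[C@H](CCC(=O)O)NC(=O)c1ccc(CNc2nc3cc(N)cc(N)c3nc2-c2ccccc2)cc1`: in a functional assay on HCC 2998 cells (Homo sapiens) for inhibition, read by sulforhodamine B assay, with a stated time of 48 h (on this read-out lower numbers stand for higher toxicity in this test and higher numbers for lower toxicity in this test), compound 1 gives < 100000 nM, which is a limit of the assay and not a number.
Compound 2 `COc1ccc(CNc2nc3cc(N)cc(N)c3nc2-c2ccccc2)cc1OC`: in this assay compound 2 gives < 100000 nM, again a limit rather than a number.
Compound 3 `CCOC(=O)[C@H](CCC(=O)O)NC(=O)c1ccc(Sc2nc3cc(N)cc(N)c3nc2-c2ccccc2)cc1`: in this assay compound 3 gives 70800 nM.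

Compound 2 stands at the limit of < 100000 nM in this assay, at which 2 of the 3 values shown sit, so where it truly falls cannot be told from what has been measured. Compound 4 `COc1ccc(CNc2nc3cc(N)cc(N)c3nc2-c2ccccc2)cc1` is the compound still to be measured. It differs from compound 2 in one place: hydrogen in place of methoxy on an aromatic carbon. Going by the values given here, no step between two measured compounds matches this change, so nothing measured tells how large the effect of removing the methoxy should be. Among the compounds with values here, with compound 2 known only as a limit, no step in this assay beyond the usual scatter is expected in either direction, and the likeliest outcome is that compound 4 again reaches only the limit. The expected value for compound 4 in this assay is 60000 nM, within 15000 nM to 100000 nM. The estimated step from compound 2 to compound 4 is a step that the limit leaves unreadable from compound 2 to compound 4, expected to stay within the scatter.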

Compound 4, concentration lethal to 50% of the cells: < 100000 nM
Compound 4: no number, only a limit; the forecaster's own chance of this, stated with the estimate: 60%; the middle value lies beyond the limit too.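

No step can be read from compound 2 to compound 4 in this assay, because each gives only a limit of the assay and not a number: the limit of < 100000 nM in this assay, at which 3 of the 4 values shown sit.

Still open, as far as these compounds go, is where compound 2 and compound 4 truly fall, and so whether going from 3,4-dimethoxyphenyl to 4-methoxyphenyl changes the result in this assay at all.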